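A few compounds are considered here, and "the series" means these few. Any claim that something is new, unique, unknown or untested is made for them only; others in the source may bear on it.

In a functional assay on DLA cells (Mus musculus) for cytotoxicity, read by LDH release, with a stated time of 48 h (a lower number here means a stronger inhibitor, a higher number a weaker inhibitor), three compounds have been measured: compound 1 `Cc1ccc(C(=O)c2ccc(OCC(=O)Nc3nc(-c4ccccc4)cs3)c(C)c2)cc1` gives 27100 nM; compound 2 `Cc1cc(C(=O)c2ccc(F)cc2)ccc1OCC(=O)Nc1nc(-c2ccccc2)cs1` gives 34700 nM; compound 3 `Cc1cc(C(=O)c2ccccc2F)ccc1OCC(=O)Nc1nc(-c2ccccc2)cs1` gives 15600 nM.

Compound 2 and compound 1 differ by methyl in place of fluoro on an aromatic carbon, and that change made a step of a 1.3-fold lower number from compound 2 to compound 1 (0.11 log units; within the scatter). Compound 4 `Cc1cc(C(=O)c2ccccc2C)ccc1OCC(=O)Nc1nc(-c2ccccc2)cs1` is not yet measured; it differs from compound 3 by methyl in place of fluoro on an aromatic carbon. The cores of compound 2 and compound 3 differ by 2-fluorophenyl in place of 4-fluorophenyl on a carbonyl carbon, a step of a 2.2-fold lower number from compound 2 to compound 3 (0.35 log units; beyond the scatter). Since the group stands para to a large group in one pair and ortho to a large group in the other, the change is the same kind of change, not the same. On the strength of the step of a 1.3-fold lower number from compound 2 to compound 1 (0.11 log units; within the scatter), the step to compound 4 is expected to be a 1.2-fold lower number from compound 3 to compound 4 (0.08 log units; within the scatter). Compound 4 is therefore estimated at 13000 nM, likely between 6000 nM and 28000 nM.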

Compound 4, half-maximal inhibitory concentration: 23700 nM
Beside the measured number, compound 4's estimate is 1.8-fold (0.26 log units) below it; measured number inside the range.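

In this assay, methyl in place of fluoro gave a 1.5-fold higher number from compound 3 to compound 4 (0.18 log units; within the scatter), while the other two steps read a 1.5-fold lower number from compound 2 to compound 4 (0.17 log units; within the scatter) and a 1.1-fold lower number from compound 1 to compound 4 (0.06 log units; within the scatter), so none of the three separates compound 4 from its neighbours. The same change on the two cores gave steps that cannot be told apart: the same change on two cores in this assay, a 1.3-fold lower number (0.11 log units; within the scatter) from compound 2 to compound 1 and a 1.5-fold higher number (0.18 log units; within the scatter) from compound 3 to compound 4, 1.9-fold (0.29 log units) apart, within the scatter of two such steps. This shows no sign of a dependence on the core, but it does not show that the change carries over with a set size or direction, as each step stays within the scatter and only two cores are shown.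

The compounds shown leave open whether chloro, methoxy or an amine on that aromatic carbon would give a step beyond the scatter.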